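The source may report more compounds than this note shows. Statements on the series, on what has been measured and on what is new or still open speak of the compounds shown alone.

Compound 1 `ClCc1ccc(Cn2cnc3c(Cl)ncnc32)cc1`, 91200 nM in a functional assay on SK-OV-3 cells (Homo sapiens) for cytotoxicity, read by sulforhodamine B assay, with a stated time of 48 h; on this read-out lower numbers stand for higher toxicity in this test and higher numbers for lower toxicity in this test
Compound 2 `ClCc1ccccc1Cn1cnc2c(Cl)nc(Cl)nc21`, 6910 nM in this assay

Among the measured compounds shown here, of the two compounds measured so far, compound 2 stands at the lower end: in this assay compound 2 gives 6910 nM, while compound 1 gives 91200 nM, a gap well beyond the scatter of repeated measurements. For the measured compounds named here, the two compounds differ in more than one place, so no single step between them can be traced.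

Compound 3 `ClCc1ccccc1Cn1cnc2c(Cl)ncnc21` has not yet been measured. It differs from compound 2 in one place: hydrogen in place of chloro on an aromatic carbon. The rest of the molecule, including the chloromethyl group on the benzyl ring and the remaining chloro on the shared core, stays the same.

Going by the values given here, because the only comparison available, between compound 1 and compound 2, mixes two changes at once, the effect of removing this single chloro cannot be read from the measured data. The expectation is a moderate shift toward lower toxicity, which in this read-out means a higher number, with compound 3 estimated at 20000 nM, in a range from 4000 nM to 100000 nM, a step of a 2.9-fold higher number from compound 2 to compound 3 (0.46 log units; beyond the scatter).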

Compound 3, concentration lethal to 50% of the cells: 85100 nM
Compound 3: middle estimate off by 4.3-fold (0.63 log units), on the low side; low and high end bracket the measured number.
By their numbers in this assay, from the lowest: compound 2; then compounds 3 and 1 (each within the scatter of the next).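

Among the compounds shown here, exchanging the chloro between two ring nitrogen atoms for hydrogen gives a 12-fold higher number from compound 2 to compound 3 (1.09 log units; beyond the scatter) in this assay, a large step and the first change in this small set that can be read at a single position. It shows that this one aromatic carbon on the shared core matters greatly in this test, since the loss of a single chlorine atom, with the rest of the molecule unchanged, accounts for the whole of this shift, and compound 3 now lies within the scatter of compound 1, which also carries hydrogen at this carbon. Nothing measured here explains why this exchange has so large an effect.

Going by these compounds, it remains open whether the chloro itself is needed at this carbon or whether other groups, such as a bromo, a methoxy group or an amine, would keep the number as low as that of compound 2. Also open, on these data alone, is what the chloromethyl group on the benzyl ring contributes, a question that a plain methyl group in its place would help to answer.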